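Imine arms on a fused core: predicting a hydroxy analogue

The source may report more compounds than this note shows. Statements on the series, on what has been measured and on what is new or still open speak of the compounds shown alone.

Measured so far in a functional assay on MCF7 cells (Homo sapiens) for cytotoxicity, read by sulforhodamine B assay, with a stated time of 48 h; on this read-out lower numbers stand for stronger inhibition and higher numbers for weaker inhibition:
compound 1 `COc1ccc(C2C(C#N)=C(N)Oc3nc(Nc4ccc(S(N)(=O)=O)cc4)sc32)cc1` gives 27500 nM;
compound 2 `COc1ccc(C2C(C#N)=C(/N=C/c3ccccc3)Oc3nc(Nc4ccc(S(N)(=O)=O)cc4)sc32)cc1` gives 33600 nM;
compound 3 `COc1ccc(C2C(C#N)=C(/N=C/c3ccc(Cl)cc3)Oc3nc(Nc4ccc(S(N)(=O)=O)cc4)sc32)cc1` gives 9550 nM.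

Among these three numbers compound 1 stands second highest, so it is among the weaker inhibitors here. Compound 4 `COc1ccc(C2C(C#N)=C(/N=C/c3ccc(O)cc3)Oc3nc(Nc4ccc(S(N)(=O)=O)cc4)sc32)cc1` is the next member of this set. It differs from compound 1 as follows: a group of 9 heavy atoms (7 carbon, 1 nitrogen, 1 oxygen; one six-membered aromatic ring of carbon only) in place of one nitrogen atom, on a double-bonded ring carbon.

Among the measured compounds shown here, two measured steps bear on this change. Replacing the amino group with a plain aromatic arm, in the step of a 1.2-fold higher number from compound 1 to compound 2 (0.09 log units; within the scatter), left the read-out essentially where it was. Adding a chlorine to that arm, in the step of a 3.5-fold lower number from compound 2 to compound 3 (0.55 log units; beyond the scatter), brought a modest gain, and the combined change a 2.9-fold lower number from compound 1 to compound 3 (0.46 log units; beyond the scatter) is also modest. Whether a hydroxyl on the arm behaves like the chlorine or like the bare ring is not shown by any measured pair, so the expectation for compound 4 is placed between these outcomes.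

Compound 4 is therefore estimated at 20000 nM, within a range of 7000 nM to 50000 nM, which corresponds to an expected step of a 1.4-fold lower number from compound 1 to compound 4 (0.14 log units; within the scatter).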

Compound 4, half-maximal inhibitory concentration: 34500 nM
Compound 4: middle estimate off by 1.7-fold (0.24 log units), on the low side, within the range that was stated.
By their numbers in this assay, from the lowest: compound 3; then compounds 1, 2 and 4 (each within the scatter of the next).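

In this assay, placing hydroxy on the aromatic ring of the imine arm leaves the read-out level with the bare ring (a 1.0-fold higher number from compound 2 to compound 4 (0.01 log units; within the scatter)). The hydroxy arm also stays level with the amino group it replaces (a 1.3-fold higher number from compound 1 to compound 4 (0.10 log units; within the scatter)). Exchanging chloro for hydroxy on the same aromatic carbon, however, separates the two arms (a 3.6-fold higher number from compound 3 to compound 4 (0.56 log units; beyond the scatter)), so the modest gain seen with compound 3 does not extend to every group on this ring: among the four compounds, only compound 3 stands apart, and compound 4 goes against any general gain from a ring substituent.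

Nothing available explains why chloro and hydroxy differ here. The compounds shown also leave open how a bromo, methoxy or dimethylamino group on this arm would compare with chloro.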